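Moving the ring nitrogen: pyridin-2-yl in place of pyridin-4-yl

The source may hold more compounds than are shown below. What is called first, only, known or untested is meant among the compounds shown, and "the series" means these compounds.

Measured compounds:
Compound 1 `Cc1cn2c(/C=N/NC(=N)N)c(-c3ccncc3)nc2s1`: 19500 nM
Compound 2 `N=C(N)N/N=C/c1c(-c2ccncc2)nc2sc(Cl)cn12`: 5890 nM

Both compounds were tested in a functional assay (Homo sapiens) for antiproliferative activity; a higher number here means a weaker inhibitor of growth, a lower number a stronger inhibitor of growth. Compound 1 gives 19500 nM, the highest of the two numbers; its nearest neighbour is compound 2 with 5890 nM, reached by a 3.3-fold lower number from compound 1 to compound 2 (0.52 log units; beyond the scatter).

Compound 3 `Cc1cn2c(/C=N/NC(=N)N)c(-c3ccccn3)nc2s1` is not yet measured. It differs from compound 1 in a single place: pyridin-2-yl in place of pyridin-4-yl on an aromatic carbon. Going by the values given here, the only measured step, chloro in place of methyl, changes a different part of the core, so nothing measured bears directly on moving the ring nitrogen of the pyridinyl group. The guess therefore rests on compound 1 alone, with a wide range in both directions.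

In this assay compound 3 is expected to give about 19000 nM, between 6000 nM and 60000 nM. The step from compound 1 to compound 3 is expected to be a 1.0-fold lower number from compound 1 to compound 3 (0.01 log units; within the scatter), not beyond the scatter.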

Compound 3, concentration for 50% growth inhibition: 9770 nM
Estimate against measurement, compound 3: 1.9-fold (0.29 log units) above, within the range that was stated.
By their numbers in this assay, from the lowest: compounds 2, 3 and 1 (each within the scatter of the next, the first and the last beyond it).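

Up to now, the only measured change was chloro in place of methyl, a 3.3-fold lower number from compound 1 to compound 2 (0.52 log units; beyond the scatter), which left the pyridinyl group untouched. Going by these compounds alone, compound 3 gives the first reading at this aromatic carbon: in this assay, pyridin-2-yl in place of pyridin-4-yl gives a 2.0-fold lower number from compound 1 to compound 3 (0.30 log units; within the scatter), so the two ring nitrogen placings cannot be told apart here and this move neither clearly helps nor clearly harms growth inhibition. No measurement shown here accounts for this result.

The compounds shown leave open how pyridin-3-yl, or a plain phenyl ring with no ring nitrogen at all, would behave at this carbon. They also leave open whether pyridin-2-yl and chloro together on the shared core would give a number different from either single change.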